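A few compounds are considered here, and "the series" means these few. Any claim that something is new, unique, unknown or untested is made for them only; others in the source may bear on it.

Measured so far:
compound 1, `Nc1nc(O)nc2ccccc12`: 4.02
compound 2, `Nc1nc(S)c2ccccc2n1`: 4.37
compound 3, `Nc1nc(O)c2cc([S+]([O-])c3ccc4ccccc4c3)ccc2n1`: 7.38

In an assay for inhibition of Dihydrofolate reductase (Homo sapiens) (on this read-out higher numbers stand for higher potency (the scale is a negative logarithm) and lower numbers for lower potency), compound 1 gives the lowest of these three numbers. Compound 2 lies a little higher, by more than the scatter, while compound 3 stands far above both. Compound 4, `Nc1nc(S)nc2ccccc12`, has not been measured. It differs from compound 1 in one place: sulfanyl in place of hydroxy on an aromatic carbon. For the measured compounds named here, no pair of measured compounds shows this exact exchange, so its size has to be guessed. Compound 2 carries a sulfanyl group elsewhere on the shared core and reads slightly higher than compound 1, which suggests at most a small upward step. For compound 4 a value of about 4.3 is expected, between 3.8 and 4.9, meaning an estimated step of a number 0.28 log units higher from compound 1 to compound 4 (within the scatter).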

Compound 4, logarithm of the reciprocal of the active concentration, log(1/C): 3.72
Compound 4: the middle estimate sits 0.58 log units above what was measured, outside the stated range (below it).
By their numbers in this assay, from the lowest: compounds 4 and 1 (each within the scatter of the next); then compound 2; then compound 3.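

In this assay, placing sulfanyl in place of hydroxy on the aromatic carbon between two ring nitrogen atoms gives a number 0.30 log units lower from compound 1 to compound 4 (within the scatter). At this position, then, exchanging one of these groups for the other produces no difference that can be told apart from repeat scatter. No measurement at hand offers an explanation for this step.

As far as these compounds go, what stays open is whether an amine, a carboxylic acid or a longer chain on this same carbon would move the number beyond the scatter, and in which direction.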